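Vero cell cytotoxicity: changing the amine on the shared core

The source may hold more compounds than are shown below. What is called first, only, known or untested is meant among the compounds shown, and "the series" means these compounds.

In an ADME assay on Vero cells (Chlorocebus sabaeus) for cytotoxicity, read by MTT assay, with a stated time of 72 h (a lower number here means a stronger inhibitor, a higher number a weaker inhibitor), compound 1 `CC1CN(c2nc3c(cc2[N+](=O)[O-])c(=O)c(C(=O)O)cn3C2CC2)CC(C)O1` is reported as > 160000 nM, which is a limit of the assay and not a number. Compound 2 `CC1CN(c2nc3c(cc2[N+](=O)[O-])c(=O)c(C(=O)O)cn3-c2ccc(F)cc2)CC(C)O1` gives 141000 nM, and compound 3 `CC1CN(c2nc3c(cc2[N+](=O)[O-])c(=O)c(C(=O)O)cn3C(C)(C)C)CC(C)O1` gives 159000 nM. Compound 3 therefore stands level with compound 2, the gap being a 1.1-fold higher number from compound 2 to compound 3 (0.05 log units; within the scatter).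

All three share the 2,6-dimethylmorpholin-4-yl group and differ only in the group on the aromatic nitrogen. Compound 4 `CC1(C)COCN1c1nc2c(cc1[N+](=O)[O-])c(=O)c(C(=O)O)cn2C(C)(C)C` keeps the tert-butyl group of compound 3 and instead carries 4,4-dimethyl-1,3-oxazolidin-3-yl in place of 2,6-dimethylmorpholin-4-yl on an aromatic carbon, ortho to a nitro group (4,4-dimethyl-1,3-oxazolidin-3-yl in place of 2,6-dimethylmorpholin-4-yl on an aromatic carbon).

Within the data shown here, no measured step changes this position, so the evidence is indirect. The nitrogen changes give an at least 1.1-fold lower number from compound 1 to compound 2 (0.05 log units; that floor lies within the scatter) and a number no higher from compound 1 to compound 3 (the limit leaves the size open), alongside the gap already noted. Among the measured compounds shown here, the series so far therefore offers no sign of a large shift, and no step beyond the scatter is expected in this assay. The expected change is a 1.2-fold lower number from compound 3 to compound 4 (0.09 log units; within the scatter). A reading reported only as a limit remains possible for compound 4. For compound 4 the estimated value is 130000 nM, with an expected range of 65000 nM to 200000 nM.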

Compound 4, half-maximal inhibitory concentration: > 160000 nM
Compound 4: no number, only a limit (the forecaster's own chance of this, stated with the estimate: 30%); middle value at least 1.2-fold (0.09 log units) away from the limit.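

Notes on the amine position: in this assay, 4,4-dimethyl-1,3-oxazolidin-3-yl in place of 2,6-dimethylmorpholin-4-yl, on an aromatic carbon ortho to a nitro group, gives a number no lower from compound 3 to compound 4 (the limit leaves the size open). The earlier compounds shown here varied only the group on the aromatic nitrogen, whereas this step shows that, with tert-butyl kept there, a five-membered non-aromatic ring can replace the six-membered one at this carbon without a lower number in this assay. The size of the step cannot be read, because the reading for compound 4 is a limit and not a number: the limit of > 160000 nM in this assay, at which 2 of the 4 values shown sit.

Still open, from the compounds shown here alone, is whether a basic open-chain amine such as dimethylamino, or a piperazin-1-yl ring with its free ring nitrogen, at this aromatic carbon would bring the reading down to a measurable number. Also open, going by these compounds, is how the series would read with an amino group in place of the nitro group, or with 4,4-dimethyl-1,3-oxazolidin-3-yl paired with cyclopropyl or 4-fluorophenyl on the aromatic nitrogen.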